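Trading the trimethoxyphenyl for an isopropyl on the amidine nitrogen

The compounds below may be only part of what the source reports. "The series", "measured", "known", "first", "only" and "open" are said of these compounds alone.

Measured compounds:
- compound 1 `Cc1ccc(S(=O)(=O)/N=C(/CCNC2=CC(=O)c3ccccc3C2=O)Nc2ccccc2I)cc1` gives 15500 nM in a functional assay on MCF7 cells (Homo sapiens) for cytotoxicity, read by MTT assay, with a stated time of 48 h; on this read-out lower numbers stand for stronger inhibition and higher numbers for weaker inhibition
- compound 2 `COc1cc(N/C(CCNC2=CC(=O)c3ccccc3C2=O)=N\S(=O)(=O)c2ccc(C)cc2)cc(OC)c1OC` gives 3050 nM in this assay

Going by the values given here, on these two numbers compound 2 stands lowest, and the only measured step, a 5.1-fold lower number from compound 1 to compound 2 (0.71 log units; beyond the scatter), separates it from compound 1 by a margin beyond the scatter. That step exchanged one aromatic ring for another on the amine nitrogen of the shared core.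

Compound 3 `Cc1ccc(S(=O)(=O)/N=C(/CCNC2=CC(=O)c3ccccc3C2=O)NC(C)C)cc1` has not yet been measured. It differs from compound 2 by isopropyl in place of 3,4,5-trimethoxyphenyl on an amine nitrogen. Among the compounds with values here, no measured step bears directly on this change: the one available step compares two aromatic groups at the same nitrogen, and gives no guide to what happens when the aromatic ring is removed altogether and a small alkyl group takes its place. Compound 2 holds the lowest number largely on the strength of the trimethoxyphenyl, so removing that group is expected to move the number back upward, plausibly toward the region of compound 1, though with wide uncertainty in both directions. Compound 3 is therefore expected at 9000 nM, within a range of 2500 nM to 35000 nM, a step of a 3.0-fold higher number from compound 2 to compound 3 (0.47 log units; beyond the scatter) in this assay.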

Compound 3, half-maximal inhibitory concentration: 16500 nM
Compound 3: the middle estimate sits 1.8-fold (0.26 log units) below what was measured, and the stated range covers the measured number.
By their numbers in this assay, from the lowest: compound 2; then compounds 1 and 3 (each within the scatter of the next).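

In this assay the change from 3,4,5-trimethoxyphenyl to isopropyl on the amine nitrogen gives a 5.4-fold higher number from compound 2 to compound 3 (0.73 log units; beyond the scatter) and so gives up the whole advantage that compound 2 held. The exchange of 2-iodophenyl for isopropyl at the same nitrogen gives a 1.1-fold higher number from compound 1 to compound 3 (0.03 log units; within the scatter) and leaves compound 1 and compound 3 indistinguishable on this read-out. The earlier pair could not show that an aromatic ring at this nitrogen does not by itself set the number: among these three compounds, 2-iodophenyl and isopropyl read alike, and only the 3,4,5-trimethoxyphenyl of compound 2 stands apart. No measurement shown gives a reason for this difference.

The compounds shown leave open whether the methoxy groups or the ring that carries them account for the lower number of compound 2, a question that unsubstituted phenyl or 4-methoxyphenyl at this nitrogen would address. They also leave open whether isopropyl marks the general level for alkyl groups here or whether a larger one, such as cyclohexyl or a longer chain, would read differently.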